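Swapping Diallyl for Cyclobutylmethyl-Ethyl on a Shared Core

This account rests on a few compounds, and the source may have more. Where it says the series, first, only, none or still open, it means among the compounds named here.

Compound 1 `CCN(Cc1c(C(F)(F)F)nc2n(-c3c(C)cc(C)cc3C)c(Cl)cn12)CC1CC1`: 9 nM in an assay on cells for displacement of a labelled ligand from corticotropin-releasing factor receptor 1 (Homo sapiens), with a stated time of 100 min; on this read-out lower numbers stand for stronger inhibition and higher numbers for weaker inhibition
Compound 2 `CCCCN(CC)Cc1c(C(F)(F)F)nc2n(-c3c(C)cc(C)cc3C)c(Cl)cn12`: 78 nM
Compound 3 `C=CCN(CC=C)Cc1c(C(F)(F)F)nc2n(-c3c(C)cc(C)cc3C)c(Cl)cn12`: 13 nM

Compound 3 sits second highest of the three numbers, close to compound 1 and well apart from compound 2. Compound 4 `CCN(Cc1c(C(F)(F)F)nc2n(-c3c(C)cc(C)cc3C)c(Cl)cn12)CC1CCC1` carries (cyclobutylmethyl)(ethyl)amino in place of diallylamino on a saturated chain carbon bound to an aromatic carbon. For the measured compounds named here, two measured steps bear on this: a 1.4-fold higher number from compound 1 to compound 3 (0.16 log units; within the scatter), and a 6.0-fold lower number from compound 2 to compound 3 (0.78 log units; beyond the scatter), showing that a ring-bearing amine and the diallyl amine give similar numbers while the open butyl chain gives a weaker one. A cyclobutylmethyl group, being a ring like that of compound 1, is therefore expected to yield roughly a 1.2-fold higher number from compound 3 to compound 4 (0.06 log units; within the scatter). Compound 4 is estimated at 15 nM, ranging from 5 nM to 60 nM.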

Compound 4, inhibition constant: 16 nM
For compound 4 the middle estimate is 1.1-fold (0.03 log units) below the measured one; the measured number falls inside the stated range.
By their numbers in this assay, from the lowest: compounds 1, 3 and 4 (each within the scatter of the next); then compound 2.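

In this assay the step of a 1.2-fold higher number from compound 3 to compound 4 (0.09 log units; within the scatter) and the step of a 1.8-fold higher number from compound 1 to compound 4 (0.25 log units; within the scatter) both stay within the scatter, so on this amine a cyclobutyl ring matches both the diallyl groups and the smaller cyclopropyl ring. The open chain stays apart, with a 4.9-fold lower number from compound 2 to compound 4 (0.69 log units; beyond the scatter) beyond the scatter. Two ring-bearing amines now separate from the butyl amine, though compound 3, with no ring, goes against any rule that a ring is required.

No evidence here explains these differences. On these data alone, whether a cyclopentylmethyl group or a morpholine at this place would give a similar number remains open.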